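Trimming the acid from compound 2

The compounds below may be only part of what the source reports. "The series", "measured", "known", "first", "only" and "open" are said of these compounds alone.

In an ADME assay on Vero cells (Chlorocebus sabaeus) for cytotoxicity (a lower number here means that less compound is tolerated, a higher number that more compound is tolerated), compound 1, `CCC(=O)Nc1ccc(-c2nc3cc(C(F)(F)F)ccc3n2C2CCCCC2)cc1`, gives only a limit, > 100000 nM. Compound 2, `O=C(O)CCC(=O)Nc1ccc(-c2nc3cc(C(F)(F)F)ccc3[nH]2)cc1`, likewise reaches only the limit of this assay, > 100000 nM. Both values therefore sit at the same boundary (the limit of > 100000 nM in this assay, at which 2 of the 2 values shown sit), so no ordering between them can be read. Compound 3, `CCC(=O)Nc1ccc(-c2nc3cc(C(F)(F)F)ccc3[nH]2)cc1`, has not yet been measured. It differs from compound 2 as follows: hydrogen in place of carboxy on a saturated chain carbon, two bonds along the chain from a carbonyl carbon. With both shown values at the limit, no step beyond the scatter is expected in this assay. Compound 3 is estimated at 100000 nM, within 40000 nM to 300000 nM, the expected step being a number no higher from compound 2 to compound 3 (the limit leaves the size open).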

Compound 3, half-maximal cytotoxic concentration: > 100000 nM
Compound 3: only a limit was reported (the forecaster's own chance of this, stated with the estimate: 70%); the middle value sits exactly at the limit.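

In this assay compound 3 gives only a limit, > 100000 nM. The steps to compound 3 from compound 1 and compound 2 therefore cannot be read: the limit of > 100000 nM in this assay, at which 3 of the 3 values shown sit.

The compounds shown leave open at what concentration any of the three would reach half-maximal cytotoxicity.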